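Swapping Fluoro for Bromo on the Aryl Ring

The compounds below may be only part of what the source reports. "The series", "measured", "known", "first", "only" and "open" are said of these compounds alone.

Compound 1 `COc1ccc(/C=C2\Cc3c(cc(OC)c(OC)c3OC)C2=O)cc1O`: 213 nM
Compound 2 `COc1ccc(/C=C2\Cc3c(cc(OC)c(OC)c3OC)C2=O)cc1[N+](=O)[O-]`: 1560 nM
Compound 3 `COc1ccc(/C=C2\Cc3c(cc(OC)c(OC)c3OC)C2=O)cc1F`: 277 nM

In a functional assay on PC-3 cells (Homo sapiens) for antiproliferative activity, read by MTT assay, with a stated time of 48 h (a lower number here means a stronger inhibitor of growth, a higher number a weaker inhibitor of growth), compound 3 gives 277 nM, the second highest of the three numbers. Compound 3 and compound 1 lie within the scatter of each other, as a 1.3-fold higher number from compound 1 to compound 3 (0.11 log units; within the scatter) shows, while the step of a 5.6-fold lower number from compound 2 to compound 3 (0.75 log units; beyond the scatter) is clearly larger. Compound 4 `COc1ccc(/C=C2\Cc3c(cc(OC)c(OC)c3OC)C2=O)cc1Br` differs from compound 3 by bromo in place of fluoro on an aromatic carbon. Within the data shown here, no measured step involves bromo. The two steps that bear on this carbon show that hydroxy and fluoro give close numbers, whereas nitro gives a markedly higher one. With no measured step beyond the scatter between the two smaller groups, compound 4 is expected to give 320 nM, with a range of 110 nM to 950 nM. The expected step is a 1.2-fold higher number from compound 3 to compound 4 (0.06 log units; within the scatter), within the scatter.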

Compound 4, concentration for 50% growth inhibition: 389 nM
The estimate for compound 4 lay 1.2-fold (0.08 log units) below the measured number, within the range that was stated.
By their numbers in this assay, from the lowest: compounds 1, 3 and 4 (each within the scatter of the next); then compound 2.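

In this assay, bromo on this aromatic carbon lies within the scatter of fluoro (a 1.4-fold higher number from compound 3 to compound 4 (0.15 log units; within the scatter)) and of hydroxy (a 1.8-fold higher number from compound 1 to compound 4 (0.26 log units; within the scatter)), so three of the four groups shown now give numbers that cannot be told apart step by step. Nitro still stands apart, this time from bromo as well (a 4.0-fold lower number from compound 2 to compound 4 (0.60 log units; beyond the scatter)). Nothing given here accounts for these numbers.

The compounds shown leave open whether an amine or a carboxylic acid on this carbon would fall with hydroxy, fluoro and bromo or with nitro.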